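Notes on a thiocarbamate ester series: compound 1 to compound 4

This account rests on a few compounds, and the source may have more. Where it says the series, first, only, none or still open, it means among the compounds named here.

The shared core of the three measured compounds carries a thiocarbamate ester on a methylene arm. Compound 1 (`O=c1c(CSC(=S)N2CCN(c3ccccc3)CC2)coc2ccccc12`) bears a phenyl group on the ring nitrogen of its amine. In a functional assay on MCF7 cells (Homo sapiens) for antiproliferative activity, read by MTT assay, with a stated time of 72 h (on this read-out lower numbers stand for stronger inhibition and higher numbers for weaker inhibition), compound 1 reaches only the limit > 30000 nM; this is a limit of the read-out and not a number. Going by the values given here, compound 2 (`O=c1cc(CSC(=S)N2CCCC2)oc2ccccc12`) is the one member that gives a number, and in this assay compound 2 gives 35800 nM. Compound 3 (`CC(C)N(C(=S)SCc1oc2ccccc2c(=O)c1Cl)C(C)C`) carries a chlorine on the core; in this assay compound 3 sits at the limit > 40000 nM, again a limit and not a number. Compound 1 thus stands with compound 3 at the weak end of what can be measured, as shown by the limit of > 30000 nM in this assay, at which 1 of the 3 values shown sits, and (the limit of > 40000 nM in this assay, at which 1 of the 3 values shown sits).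

Compound 4 (`CN1CCN(C(=S)SCc2coc3ccccc3c2=O)CC1`) differs from compound 1 by methyl in place of phenyl on an amine nitrogen in a ring; in words, methyl in place of phenyl on an amine nitrogen in a ring. Among the compounds with values here, no measured pair shows this change, and every measured compound lies at or near the limit, so no direction beyond the scatter is expected: the step that the limit leaves unreadable from compound 1 to compound 4 is expected to be flat. Compound 4 is estimated at 40000 nM, within 15000 nM to 120000 nM, most likely reported as a limit.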

Compound 4, half-maximal inhibitory concentration: 22900 nM
Beside the measured number, compound 4's estimate is 1.7-fold (0.24 log units) above it, within the range that was stated.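

In this assay compound 4 gives 22900 nM, a number and not a limit, so this amine nitrogen in a ring now has one measured end to the change. Methyl in place of phenyl on an amine nitrogen in a ring gives an at least 1.3-fold lower number from compound 1 to compound 4 (0.11 log units; that floor lies within the scatter), so the first step readable at this position shows that taking away the phenyl does not push the read-out past the measurable range, while the floor of the step claims no gain beyond the scatter. The true size of the step cannot be read, because compound 1 stands only at a limit: the limit of > 30000 nM in this assay, at which 1 of the 4 values shown sits.

Going by these compounds, whether a hydrogen, an ethyl or a benzyl group on this nitrogen would give a number close to that of compound 4 stays open, so it cannot yet be said whether methyl itself matters or only the absence of phenyl. Going by these compounds alone, also open is whether the same change would read alike with the other amines and on the other cores, as compound 2 and compound 3 differ from compound 4 in more than one place and offer no step.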